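Mirror-image diepoxide: what inversion may do

The source may hold more compounds than are shown below. What is called first, only, known or untested is meant among the compounds shown, and "the series" means these compounds.

- Compound 1 `Cc1cc(=O)c2c(O)cc(OC[C@@H]3CO3)cc2o1`: 17500 nM
- Compound 2 `Cc1cc(=O)c2c(OC[C@@H]3CO3)cc(OC[C@@H]3CO3)cc2o1`: 39500 nM
- Compound 3 `Cc1cc(=O)c2c(OC[C@@H]3CO3)cc(OC[C@H]3CO3)cc2o1`: 12100 nM

In a functional assay on HCT-15 cells (Homo sapiens) for antiproliferative activity, with a stated time of 48 h (a higher number here means a weaker inhibitor, a lower number a stronger inhibitor), compound 3 gives 12100 nM, which lies within the scatter of compound 1 and clearly below compound 2 at 39500 nM. Compound 3 therefore sits at the more potent end of this small set, a place it shares with compound 1.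

The change to compound 4 `Cc1cc(=O)c2c(OC[C@H]3CO3)cc(OC[C@@H]3CO3)cc2o1` adds and removes nothing: the two compounds have the same atoms and bonds and differ only in configuration as drawn: 2 of 2 stereo elements differ (all stereocentres are inverted: mirror images); a stereocentre at a saturated ring carbon is drawn S in compound 3 and R in compound 4; a stereocentre at a saturated ring carbon is drawn R in compound 3 and S in compound 4.

The measured step that bears most directly on this is a 3.3-fold lower number from compound 2 to compound 3 (0.51 log units; beyond the scatter), which is modest but beyond the scatter. It can come only from configuration because of the fact that compounds 2 and 3 differ only in the configuration as drawn. That step inverted one stereocentre, whereas the step to compound 4 inverts both, so configuration clearly matters here, but the size of a double inversion has not been measured. The other step, a 2.3-fold higher number from compound 1 to compound 2 (0.35 log units; beyond the scatter), adds a whole group and says little about mirror images.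

Since compound 3 at 12100 nM stands at the low end of the numbers, a modest move towards a higher number seems more likely than a further drop. The expected step is a 2.1-fold higher number from compound 3 to compound 4 (0.32 log units; beyond the scatter). For compound 4 the estimated value is 25000 nM, with an expected range of 9000 nM to 60000 nM.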

Compound 4, half-maximal inhibitory concentration: 9590 nM
For compound 4 the middle estimate is 2.6-fold (0.42 log units) above the measured one, within the range that was stated.
By their numbers in this assay, from the lowest: compounds 4, 3 and 1 (each within the scatter of the next); then compound 2.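

The mirror-image pair shows that inverting both stereocentres at once leaves this assay unable to tell the two compounds apart, with a 1.3-fold lower number from compound 3 to compound 4 (0.10 log units; within the scatter), and this comparison isolates configuration alone: the fact that compounds 3 and 4 differ only in the configuration as drawn. Compound 2 has both stereocentres drawn S, while compounds 3 and 4 each carry one drawn R and one drawn S, and the second single inversion gives a 4.1-fold lower number from compound 2 to compound 4 (0.61 log units; beyond the scatter), so inverting either centre of compound 2 moves the number the same way, a gap that can only come from configuration: the fact that compounds 2 and 4 differ only in the configuration as drawn. Placing (oxiran-2-yl)methyl on the free oxygen of compound 1 also reads differently now, since a 1.8-fold lower number from compound 1 to compound 4 (0.26 log units; within the scatter) stays within the scatter while a 2.3-fold higher number from compound 1 to compound 2 (0.35 log units; beyond the scatter) does not, so the outcome of adding this group depends on how it is drawn.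

Going by these compounds, the compound with both stereocentres drawn R, the mirror image of compound 2, remains open, and it would show whether matching configurations or the S configuration itself goes with the higher number. Also open, on these data alone, is whether the epoxide matters at all, as a plain methyl, a longer chain or an amine on the same oxygen could show.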